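Butyl to propyl on the shared core

A few compounds are considered here, and "the series" means these few. Any claim that something is new, unique, unknown or untested is made for them only; others in the source may bear on it.

Compound 3 `CCCCc1cc(OC)nc2nc(C(=O)c3ccccc3)cn12` stands in a functional assay on the whole organism with Rattus norvegicus as the target (on this read-out higher numbers stand for an effect only at larger amounts of compound and lower numbers for an effect already at smaller amounts), at 10 mg/kg, level at the digits shown with compound 1 `CCCc1cc(SC)nc2nc(C(=O)c3ccccc3)cn12`, which gives 10 mg/kg; together they carry the highest numbers of the three measured. The lowest belongs to compound 2 `CCc1cc(OC)nc2nc(C(=O)c3ccccc3)cn12`, which in this assay gives 2 mg/kg. Going by the values given here, the only step between compounds differing in one place is a 5.0-fold higher number from compound 2 to compound 3 (0.70 log units; beyond the scatter), ethyl in place of hydrogen on a saturated chain carbon, two bonds along the chain from an aromatic carbon. Compound 1 and compound 3 differ in two places; their values show no change at the digits shown.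

Compound 4 `CCCc1cc(OC)nc2nc(C(=O)c3ccccc3)cn12` differs from compound 3 by hydrogen in place of methyl on a saturated chain carbon, three bonds along the chain from an aromatic carbon. Cut one bond further out this reads butyl to propyl, so compound 4 sits partway along the chain lengthening that separates compound 2 from compound 3. Among the compounds with values here, a partial reversal of that modest step is expected, because the only direct guide is a 5.0-fold higher number from compound 2 to compound 3 (0.70 log units; beyond the scatter), while compound 1, carrying propyl beside a different group, gives 10 mg/kg, a warning that propyl need not lower the number. The expected step is a 2.0-fold lower number from compound 3 to compound 4 (0.30 log units; within the scatter), toward the lower side, possibly within the scatter. Compound 4 is estimated at 5 mg/kg in this assay, with a range from 2 mg/kg to 10 mg/kg.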

Compound 4, minimum effective dose: 1 mg/kg
Estimate against measurement, compound 4: 5.0-fold (0.70 log units) above, and the stated range ends above it.
By their numbers in this assay, from the lowest: compounds 4 and 2 (each within the scatter of the next); then compounds 1 and 3 (each within the scatter of the next).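

In this assay, hydrogen in place of methyl on a saturated chain carbon, three bonds along the chain from an aromatic carbon, gives a 10-fold lower number from compound 3 to compound 4 (1.00 log units; beyond the scatter), so the last carbon of the butyl chain carries a step beyond the scatter. Shortening the chain further does not continue the trend: a 2.0-fold lower number from compound 2 to compound 4 (0.30 log units; within the scatter) leaves ethyl and propyl unresolved on the methoxy compounds, and among the chains shown, the higher number goes with butyl alone. Going by these compounds alone, the first one-place reading of the other substituent, with propyl held constant, is a 10-fold lower number from compound 1 to compound 4 (1.00 log units; beyond the scatter), which shows that propyl is compatible with a low number when methoxy replaces methylsulfanyl and ties the high number of compound 1 to methylsulfanyl in this pair.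

Open, as far as these compounds go, are whether a longer chain such as pentyl, a branched chain such as isopropyl, or an amine at the chain end would stay with ethyl and propyl or go with butyl, and whether methylsulfanyl gives a step of similar size on ethyl or butyl. The data at hand offer no independent measurement that accounts for either large step.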